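A few compounds are considered here, and "the series" means these few. Any claim that something is new, unique, unknown or untested is made for them only; others in the source may bear on it.

Compound 1 `COc1cc(-c2ccnc3cc(-c4ccc(C)cc4)nn23)cc(OC)c1OC` is the reference point of the series: in a functional assay on HCT-116 cells (Homo sapiens) for inhibition, read by CCK-8 assay, with a stated time of 48 h (on this read-out higher numbers stand for weaker inhibition and lower numbers for stronger inhibition), compound 1 gives 48 nM. Compound 2 `COc1cc(-c2ccnc3cc(-c4ccc(C(C)(C)C)cc4)nn23)cc(OC)c1OC` carries tert-butyl in place of methyl on an aromatic carbon, and the limit of > 10000 nM in this assay, at which 1 of the 3 values shown sits, concerns compound 2 alone: in this assay compound 2 gives only a limit, > 10000 nM. Compound 3 `COc1cc(-c2ccnc3cc(-c4ccc(C(C)=O)cc4)nn23)cc(OC)c1OC` carries acetyl in place of methyl on an aromatic carbon, and in this assay compound 3 gives 4390 nM. Among the actual numbers compound 3 stands highest, its nearest neighbour being compound 1 with a 91-fold higher number from compound 1 to compound 3 (1.96 log units; beyond the scatter), while compound 2 sits at a limit. The step of an at least 2.2-fold lower number from compound 2 to compound 3 (0.35 log units; beyond the scatter) is at least modest, and an at least 200-fold higher number from compound 1 to compound 2 (2.31 log units; beyond the scatter) is large.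

Compound 4 `COc1ccc(-c2cc3nccc(-c4cc(OC)c(OC)c(OC)c4)n3n2)cc1F` is the next step: 3-fluoro-4-methoxyphenyl in place of 4-acetylphenyl on an aromatic carbon. For the measured compounds named here, no measured step exchanges the acetyl for a fluoro-methoxy substituent, so the bearing is indirect. Compound 1 with methyl gives 48 nM, whereas tert-butyl in compound 2 and acetyl in compound 3 both give far higher numbers. The entering group, like methyl in compound 1 and unlike acetyl in compound 3, holds no double bond outside aromatic rings, so a return toward the number of compound 1 is expected. Compound 4 is estimated to give 150 nM, with a likely range from 20 nM to 2000 nM. Compound 4 is thus expected to show a 29-fold lower number from compound 3 to compound 4 (1.47 log units; beyond the scatter).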

Compound 4, half-maximal inhibitory concentration: 2840 nM
The estimate for compound 4 lay 19-fold (1.28 log units) below the measured number; measured number outside the range, above it.
By their numbers in this assay, from the lowest: compound 1; then compounds 4 and 3 (each within the scatter of the next). At a limit, above all of these: compound 2.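

In this assay, placing 3-fluoro-4-methoxyphenyl instead of 4-acetylphenyl on this aromatic carbon of the five-membered aromatic ring gives a 1.5-fold lower number from compound 3 to compound 4 (0.19 log units; within the scatter), so losing the double bond outside aromatic rings does not by itself bring the number back toward that of the methyl reference. The gap to the reference remains wide, a 59-fold higher number from compound 1 to compound 4 (1.77 log units; beyond the scatter), and with this step all three exchanges away from 4-methylphenyl shown at this place (to 4-(tert-butyl)phenyl, 4-acetylphenyl and 3-fluoro-4-methoxyphenyl) end far from compound 1, with no compound shown going against this. The remaining step, an at least 3.5-fold lower number from compound 2 to compound 4 (0.54 log units; beyond the scatter), rests on a limit and not on a number: the limit of > 10000 nM in this assay, at which 1 of the 4 values shown sits.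

The compounds shown leave open how a phenyl carrying methoxy alone or fluorine alone would read, so the two substituents of compound 4 cannot be separated. Also open, as far as these compounds go, is whether anything other than methyl on that phenyl ring, such as ethyl, chlorine or an amine, would stay close to compound 1 at 48 nM.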